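A few compounds are considered here, and "the series" means these few. Any claim that something is new, unique, unknown or untested is made for them only; others in the source may bear on it.

Compound 1 `O=C(NCCNS(=O)(=O)c1ccc(-c2ccccc2OCc2cccc(O)c2)s1)Nc1cc(Cl)cc(Cl)c1` is tested in a functional assay on HL-60 cells (Homo sapiens) for inhibition, read by CCK-8 assay, with a stated time of 48 h; on this read-out lower numbers stand for stronger inhibition and higher numbers for weaker inhibition. Compound 1 gives 2800 nM. Compound 3 `COc1ccc(Oc2ccccc2-c2ccsc2S(=O)(=O)NCCNC(=S)Nc2cc(C(F)(F)F)cc(C(F)(F)F)c2)cc1OC` gives 2800 nM, level with compound 1 at the digits shown, so the two sit within the scatter of each other. Compound 2 `COc1ccc(Oc2ccc([N+](=O)[O-])cc2-c2ccsc2S(=O)(=O)N2CCN(C(=S)Nc3ccc([N+](=O)[O-])cc3)CC2)cc1OC` returns only a limit, > 50000 nM, and the limit of > 50000 nM in this assay, at which 1 of the 3 values shown sits, marks where that limit lies. Compound 4 `O=C(NCCNS(=O)(=O)c1ccc(-c2ccccc2OCc2ccccc2)s1)Nc1cc(Cl)cc(Cl)c1` has not yet been measured and differs from compound 1 in one place: hydrogen in place of hydroxy on an aromatic carbon. No measured pair shows this same change, so nothing shown fixes its size. In this assay only a small step is expected, either none beyond the scatter or a mild move toward weaker inhibition. Compound 4 is estimated at 3500 nM, between 1200 nM and 10000 nM. The expected step is a 1.3-fold higher number from compound 1 to compound 4 (0.10 log units; within the scatter).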

Compound 4, half-maximal inhibitory concentration: 11700 nM
Estimate against measurement, compound 4: 3.3-fold (0.52 log units) below; the whole stated range lies below it.
By their numbers in this assay, from the lowest: compounds 1 and 3 (each within the scatter of the next); then compound 4. At a limit, above all of these: compound 2.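

In this assay replacing the hydroxy of the 3-hydroxybenzyl group with hydrogen gives a 4.2-fold higher number from compound 1 to compound 4 (0.62 log units; beyond the scatter) and so weaker inhibition. The earlier compounds shown here differ from one another in more than one place, so none of them could show that this single group on the aromatic ring counts. Nothing measured here explains the step.

On these data alone, whether an amine or a carboxylic acid in the same place would match the hydroxy stays open. So does whether a longer chain carrying the hydroxy would hold or lose the inhibition.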